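The source may hold more compounds than are shown below. What is called first, only, known or untested is meant among the compounds shown, and "the series" means these compounds.

Measured so far:
compound 1 `C=C(C)C(=O)Nc1cccc(-c2nc3ccccc3s2)c1` — in an ADME assay on HepG2 cells (Homo sapiens) for inhibition, with a stated time of 72 h (on this read-out higher numbers stand for an effect only at larger amounts of compound and lower numbers for an effect already at smaller amounts), compound 1 gives > 25000 nM, which is a limit of the assay and not a number.
compound 2 `O=C(Nc1cccc(-c2nc3ccccc3s2)c1)c1ccnc(Cl)c1` — in this assay compound 2 gives > 25000 nM, likewise a limit of the assay.

Compound 2 thus stands only at a limit, and both values shown sit at that same limit (the limit of > 25000 nM in this assay, at which 2 of the 2 values shown sit). The step that the two limits leave unreadable from compound 1 to compound 2 cannot be read from the two limits. Compound 3 `O=C(Nc1cccc(-c2nc3ccccc3s2)c1)c1cnc(Cl)s1` differs from compound 2 by 2-chloro-1,3-thiazol-5-yl in place of 2-chloropyridin-4-yl on a carbonyl carbon. Among the measured compounds shown here, the one measured step, from compound 1 to compound 2, bears on this only in that it also exchanged the group on the carbonyl carbon and left the read-out at the limit; its size stays unknown. For compound 3 in this assay a step that the limit leaves unreadable from compound 2 to compound 3 is expected, meaning no readable change beyond the scatter and most likely again a limit. Compound 3 is estimated at 40000 nM, with a range from 20000 nM to 100000 nM.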

Compound 3, half-maximal effective concentration: > 25000 nM
Compound 3: a limit, no number; the forecaster's own chance of this, stated with the estimate: 80%; the middle value lies beyond the limit too.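

In this assay compound 1, compound 2 and compound 3 all stand at one limit of the assay and give no number, so no step among them can be read: the limit of > 25000 nM in this assay, at which 3 of the 3 values shown sit.

The compounds shown leave open how far beyond that limit each lies, and whether any group on the carbonyl carbon changes this read-out.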